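Swapping methyl for methoxycarbonyl on a tolerated compound

The source may hold more compounds than are shown below. What is called first, only, known or untested is meant among the compounds shown, and "the series" means these compounds.

Measured in an ADME assay on MT4 cells (Homo sapiens) for cytotoxicity, read by MTT assay; a higher number here means that more compound is tolerated, a lower number that less compound is tolerated:
Compound 1 `COC(=O)c1ccc(NC(=O)CSc2nncnc2-c2cccc3ccccc23)c(Br)c1`: 173000 nM
Compound 2 `CC(=O)c1ccc(NC(=O)CSc2nncnc2-c2ccccc2Cl)c(Br)c1`: 34000 nM
Compound 3 `Cc1ccc(NC(=O)CSc2nncnc2-c2ccccc2Cl)c(Br)c1`: 45000 nM

Compound 3, at 45000 nM, lies within the scatter of compound 2, while compound 1 stands higher than both, beyond the scatter. Compound 4 `COC(=O)c1ccc(NC(=O)CSc2nncnc2-c2ccccc2Cl)c(Br)c1` differs from compound 3 in one place, with methoxycarbonyl in place of methyl on an aromatic carbon, meta to a bromo group and para to a large group: methoxycarbonyl in place of methyl on an aromatic carbon. Within the data shown here, the only measured step that bears on this carbon is a 1.3-fold higher number from compound 2 to compound 3 (0.12 log units; within the scatter), a methyl in place of acetyl. Among the measured compounds shown here, compound 1 also carries methoxycarbonyl, but it differs from compound 4 elsewhere, so the value of compound 1 at 173000 nM gives no direct step for this change. No step beyond the scatter is therefore expected in this assay. The expected change is a 1.1-fold higher number from compound 3 to compound 4 (0.05 log units; within the scatter), an estimated step that stays within the scatter. Compound 4 is expected at 50000 nM, with an estimated range of 22000 nM to 110000 nM.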

Compound 4, half-maximal cytotoxic concentration: 59000 nM
Beside the measured number, compound 4's estimate is 1.2-fold (0.07 log units) below it; the range from low to high includes it.
By their numbers in this assay, from the lowest: compounds 2, 3 and 4 (each within the scatter of the next); then compound 1.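

In this assay the carbon para to a large group now carries methoxycarbonyl as well as methyl and acetyl, and on the 2-chlorophenyl compounds these stay close: methoxycarbonyl in place of methyl stays within the scatter (a 1.3-fold higher number from compound 3 to compound 4 (0.12 log units; within the scatter)), as does methoxy in place of methyl on the carbonyl carbon (a 1.7-fold higher number from compound 2 to compound 4 (0.24 log units; within the scatter)). Among these compounds, with methoxycarbonyl held fixed, 2-chlorophenyl in place of naphthalen-1-yl gives the only new step beyond the scatter (a 2.9-fold lower number from compound 1 to compound 4 (0.47 log units; beyond the scatter)), so that difference lies at the other aromatic carbon and not at this position. No measurement offered here accounts for either finding.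

Going by these compounds, whether an amine or a carboxylic acid on this carbon would stay as close to compound 3 remains open. So does whether naphthalen-1-yl would give a similar step with methyl or acetyl on this carbon.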